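Chain-end substitution in the chloropyrimidine methylamine series

The compounds below may be only part of what the source reports. "The series", "measured", "known", "first", "only" and "open" are said of these compounds alone.

Measured so far:
compound 1 `COc1ccc(N(C)c2ccnc(Cl)n2)cc1[N+](=O)[O-]`: 8120 nM
compound 2 `COc1ccc(N(C)c2ccnc(Cl)n2)cc1OCCCCBr`: 992 nM

In a functional assay on MDA-MB-231 cells (Homo sapiens) for antiproliferative activity, read by MTT assay, with a stated time of 48 h (a lower number here means a stronger inhibitor, a higher number a weaker inhibitor), compound 2 gives the lowest number of the two; its nearest neighbour is compound 1, which differs by an 8.2-fold lower number from compound 1 to compound 2 (0.91 log units; beyond the scatter). Within the data shown here, that single step swaps nitro for 4-bromobutoxy on an aromatic carbon and is the only comparison at hand.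

Compound 3 `COc1ccc(N(C)c2ccnc(Cl)n2)cc1OCCCC[Se]C#N` keeps the 4-bromobutoxy skeleton of compound 2 and alters only the chain terminus: a group of 3 heavy atoms (1 carbon, 1 nitrogen, 1 selenium; no ring) in place of one bromine atom, on a saturated chain carbon, four bonds along the chain from an oxygen on an aromatic ring. The bromine at the end of the chain gives way to a group with a triple bond outside aromatic rings and one hydrogen-bond acceptor.

Among the measured compounds shown here, no measured step touches this position; the step from compound 1 to compound 2 changed the aromatic substituent itself, not the end of the chain, so it gives no direct guide. With nothing to point either way, the expected step in this assay is a 1.3-fold lower number from compound 2 to compound 3 (0.12 log units; within the scatter), within the scatter. For compound 3 the estimate is 750 nM, with a range of 250 nM to 2200 nM.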

Compound 3, half-maximal inhibitory concentration: > 10000 nM
Compound 3: a limit, no number; the forecaster's own chance of this, stated with the estimate: 3%; at least 13-fold (1.12 log units) between middle value and limit.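

In this assay compound 3 is recorded only as a limit of the assay, not as a number: the limit of > 10000 nM in this assay, at which 1 of the 3 values shown sits.
Among these compounds, the end of the chain, which no earlier step touched, is not a silent position: a group of 3 heavy atoms (1 carbon, 1 nitrogen, 1 selenium; no ring) in place of one bromine atom gives an at least 10-fold higher number from compound 2 to compound 3 (1.00 log units; beyond the scatter). Measured against the nitro group on the shared core, the reading is an at least 1.2-fold higher number from compound 1 to compound 3 (0.09 log units; that floor lies within the scatter), so the gain held by compound 2 does not survive this change at the chain end.

On these data alone, how far the true value lies past the limit remains open, as does whether the selenium, the nitrile or the departure of the bromine accounts for the drop. A thiocyanate, an amine or a carboxylic acid at the chain end, or a longer chain carrying the same selenium group, would help separate these.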